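The compounds below may be only part of what the source reports. "The series", "measured", "known", "first", "only" and "open" are said of these compounds alone.

Measured so far:
Compound 1 `COc1ccc(-c2nc(/N=C(\N)NC(C)C)sc2-c2ccc(OC)cc2)cc1`: 9.1 uM
Compound 2 `COc1ccc(-c2nc(CNC(=O)CSc3ccccc3)sc2-c2ccc(OC)cc2)cc1`: 4.2 uM

In a functional assay (aorta) with Rattus norvegicus as the target (a lower number here means that less compound is needed, a higher number that more compound is needed for the effect), compound 2 has the lower of the two numbers, at 4.2 uM. The gap to compound 1, at 9.1 uM, lies beyond the usual scatter, so less of compound 2 is needed for the effect.

The next compound to consider is compound 3 `COc1ccc(-c2nc(CNC(=O)CSC)sc2-c2ccc(OC)cc2)cc1`. It keeps the rest of compound 2 but carries methyl in place of phenyl on a sulfur.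

Within the data shown here, no measured pair shows what this exchange does in this assay, so any forecast is uncertain. A moderate move toward a higher number seems most likely, meaning that more compound would be needed. The expected change is a 1.9-fold higher number from compound 2 to compound 3 (0.28 log units; within the scatter). For compound 3 the estimated value is 8 uM, with an expected range from 2.5 uM to 25 uM.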

Compound 3, concentration for half-maximal effect: 6 uM
Estimate against measurement, compound 3: 1.3-fold (0.12 log units) above; measured number inside the range.
By their numbers in this assay, from the lowest: compounds 2, 3 and 1 (each within the scatter of the next, the first and the last beyond it).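

In this assay, methyl in place of phenyl on a sulfur gives a 1.4-fold higher number from compound 2 to compound 3 (0.15 log units; within the scatter), so at this position the loss of the whole aromatic ring, leaving a single carbon, produces no change that can be told from the scatter. The wider exchange on the aromatic carbon of the core, where the sulfur-bearing amide chain of compound 3 stands in place of the nitrogen-rich group of compound 1, gives a 1.5-fold lower number from compound 1 to compound 3 (0.18 log units; within the scatter), and this difference also cannot be told from the scatter. Nothing available explains why either exchange leaves so little mark on the number.

Still open, going by these compounds, is whether a longer chain such as butyl, a benzyl group or a carboxylic acid on the sulfur would move the number beyond the scatter. On these data alone, it is also open what would happen if an oxygen took the place of the sulfur itself.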